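The source may report more compounds than this note shows. Statements on the series, on what has been measured and on what is new or still open speak of the compounds shown alone.

Compound 1 `CCOC(=O)c1nnn([C@@H]2O[C@H](COC(C)=O)[C@@H](OC(C)=O)[C@H]2OC(C)=O)c1I` gives > 10000 nM in a functional assay on K562 cells (Homo sapiens), read by XTT assay, with a stated time of 48 h (a higher number here means a weaker inhibitor, a lower number a stronger inhibitor), which is a limit of the assay and not a number. Compound 2 `CCOC(=O)C#Cc1c(C(=O)OCC)nnn1[C@@H]1O[C@H](COC(C)=O)[C@@H](OC(C)=O)[C@H]1OC(C)=O` gives 700 nM, the higher of the two actual numbers, and compound 3 `CCOC(=O)C#Cc1c(C(=O)OCC)nnn1[C@H]1C[C@H](OC(C)=O)[C@@H](COC(C)=O)O1` gives 200 nM. Placing 2-(ethoxycarbonyl)ethynyl where iodo stood brings an at least 14-fold lower number from compound 1 to compound 2 (1.15 log units; beyond the scatter), which is large, and hydrogen in place of acetoxy brings a 3.5-fold lower number from compound 2 to compound 3 (0.54 log units; beyond the scatter), which is modest.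

Compound 4 `CCOC(=O)C#Cc1c(C(=O)OCC)nnn1[C@H]1O[C@@H](COC(C)=O)[C@H](OC(C)=O)[C@@H]1OC(C)=O` is the mirror image of compound 2: the two compounds have the same atoms and bonds and differ only in configuration as drawn: 4 of 4 stereo elements differ (all stereocentres are inverted: mirror images); a stereocentre at a saturated ring carbon is drawn R in compound 2 and S in compound 4; a stereocentre at a saturated ring carbon is drawn R in compound 2 and S in compound 4; a stereocentre at a saturated ring carbon is drawn R in compound 2 and S in compound 4; a stereocentre at a saturated ring carbon is drawn R in compound 2 and S in compound 4. Going by the values given here, no measured step inverts a stereocentre. Only the modest 3.5-fold lower number from compound 2 to compound 3 (0.54 log units; beyond the scatter) touches a saturated ring carbon, so a similarly modest rise in this assay is tentatively expected, meaning a 2.1-fold higher number from compound 2 to compound 4 (0.33 log units; beyond the scatter). The expected value for compound 4 is 1500 nM, within an estimated range of 300 nM to 8000 nM.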

Compound 4, half-maximal inhibitory concentration: 200 nM
Estimate against measurement, compound 4: 7.5-fold (0.88 log units) above; the whole stated range lies above it.
By their numbers in this assay, from the lowest: compounds 3 and 4 (each within the scatter of the next); then compound 2. At a limit, above all of these: compound 1.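

Inverting all four stereocentres, with no atom or bond changed, gives a 3.5-fold lower number from compound 2 to compound 4 (0.54 log units; beyond the scatter) in this assay. Going by these compounds alone, every earlier step swapped one group for another, so this is the first sign that configuration at the saturated ring carbons matters on its own. No change of group can account for this step: the fact that compounds 2 and 4 differ only in the configuration as drawn.

Which of the four stereocentres carries the step stays open, as all four invert together. Also open, as far as these compounds go, is whether a free hydroxyl group in place of the acetoxy groups would show the same dependence on configuration.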